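The compounds below may be only part of what the source reports. "The series", "measured", "known", "first", "only" and "open" are said of these compounds alone.

Measured in a functional assay on HeLa cells (Homo sapiens) for cytotoxicity, read by resazurin assay, with a stated time of 72 h; a lower number here means a stronger inhibitor, a higher number a weaker inhibitor:
- Compound 1 `CCOC(=S)SCC(=O)c1ccc(NC(C)=O)cc1`: 3610 nM
- Compound 2 `CCSC(=S)SCC(=O)c1cccc(S(=O)(=O)Nc2cccc(C(N)=O)c2)c1`: 7740 nM
- Compound 3 `CCSC(=S)SCC(=O)c1ccc(-c2ccc(N)cn2)s1`: 452 nM

Compound 2, at 7740 nM, has the highest number of the three and is therefore the weakest inhibitor so far. Compound 1 is its nearest neighbour, and compound 3 lies furthest away. These three compounds differ in more than one place, so no measured single change is available as a guide.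

Compound 4 `CCSC(=S)SCC(=O)c1cccc(S(=O)(=O)Nc2ccc(OC)cc2)c1` is still to be measured in this assay. It keeps the core of compound 2 and carries 4-methoxyphenyl in place of 3-carbamoylphenyl on a sulfonamide nitrogen. Compound 2 sits at the top of the small range, with 7740 nM, so a modest move toward a lower number seems more likely than a move higher, though the support for this is thin. The expected change is a 2.2-fold lower number from compound 2 to compound 4 (0.34 log units; beyond the scatter). For compound 4 the estimated value is 3500 nM, with an expected range from 1200 nM to 10000 nM.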

Compound 4, half-maximal inhibitory concentration: 5170 nM
For compound 4 the middle estimate is 1.5-fold (0.17 log units) below the measured one; the range from low to high includes it.
By their numbers in this assay, from the lowest: compound 3; then compounds 1, 4 and 2 (each within the scatter of the next, the first and the last beyond it).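

In this assay, among the compounds shown here, this is the first single-place comparison in the set: 4-methoxyphenyl in place of 3-carbamoylphenyl on a sulfonamide nitrogen gives a 1.5-fold lower number from compound 2 to compound 4 (0.18 log units; within the scatter) and so does not separate the two compounds. At this position, then, losing the carbamoyl group and its hydrogen-bond donor leaves the number indistinguishable from that of compound 2, and a large shift does not accompany this particular exchange. No measurement is available that would explain this result.

Only these two groups are shown on the sulfonamide nitrogen, so it stays open whether a 4-aminophenyl, a 4-carboxyphenyl or a plain methyl there would move the number beyond the scatter. From the compounds shown here alone, it also stays open whether the same exchange would give a similar step on a different core.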